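Swapping the sulfur substituent: an ester gives way to a ring

This account rests on a few compounds, and the source may have more. Where it says the series, first, only, none or still open, it means among the compounds named here.

The measured compounds are:
- compound 1 `CC(C(=O)NCc1ccc(C(F)(F)F)nc1SCCOc1ccccc1)c1ccc(NS(C)(=O)=O)c(F)c1`, which in an assay on CHO-K1 cells for antagonist activity at transient receptor potential cation channel subfamily V member 1 (Homo sapiens), read by FLIPR (on this read-out higher numbers stand for weaker inhibition and lower numbers for stronger inhibition), gives 118 nM
- compound 2 `CC1CCN(CCCSc2nc(C(F)(F)F)ccc2CNC(=O)C(C)c2ccc(NS(C)(=O)=O)c(F)c2)CC1`, which in this assay gives 217 nM
- compound 3 `COC(=O)CCSc1nc(C(F)(F)F)ccc1CNC(=O)C(C)c1ccc(NS(C)(=O)=O)c(F)c1`, which in this assay gives 1100 nM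

Compound 3 has the highest number of the three, so it is the weakest inhibitor here; its steps to the other two are both beyond the scatter. Compound 4 `CC1CCC(Sc2nc(C(F)(F)F)ccc2CNC(=O)C(C)c2ccc(NS(C)(=O)=O)c(F)c2)CC1` differs from it by 4-methylcyclohexyl in place of 2-(methoxycarbonyl)ethyl on a sulfur. Within the data shown here, the steps that bear on this change both end at compound 3: a 9.3-fold higher number from compound 1 to compound 3 (0.97 log units; beyond the scatter) and a 5.1-fold higher number from compound 2 to compound 3 (0.70 log units; beyond the scatter), while a 1.8-fold higher number from compound 1 to compound 2 (0.26 log units; within the scatter). In both measured steps, replacing a larger group with the methoxycarbonyl group raised the number. The new change removes that methoxycarbonyl group again and puts a ring in its place, so a step downward of similar size is expected, bringing compound 4 back toward compounds 1 and 2. Compound 4 is therefore expected to give about 200 nM, with a likely range from 60 nM to 700 nM. This estimate corresponds to an expected step of a 5.5-fold lower number from compound 3 to compound 4 (0.74 log units; beyond the scatter).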

Compound 4, half-maximal inhibitory concentration: 180 nM
Beside the measured number, compound 4's estimate is 1.1-fold (0.05 log units) above it; the range from low to high includes it.
By their numbers in this assay, from the lowest: compounds 1, 4 and 2 (each within the scatter of the next); then compound 3.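

Among these compounds, putting 4-methylcyclohexyl on the sulfur in place of 2-(methoxycarbonyl)ethyl gives a 6.1-fold lower number from compound 3 to compound 4 (0.79 log units; beyond the scatter) in this assay, the first step at this position that removes the ester rather than adding it. Compound 4 cannot be told apart from the two compounds with other sulfur substituents, with a 1.2-fold lower number from compound 2 to compound 4 (0.08 log units; within the scatter) and a 1.5-fold higher number from compound 1 to compound 4 (0.18 log units; within the scatter), both within the scatter. Across these four compounds, then, a ring of carbon only sitting on the sulfur does as well as a 2-phenoxyethyl or a 3-(4-methylpiperidin-1-yl)propyl chain, and only the compound carrying methoxycarbonyl stands apart.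

Nothing given here explains why the ester-bearing compound alone stands apart. On these data alone, whether a carboxylic acid or an amide at the end of that chain, or a plain cyclohexyl ring without the methyl, would track compound 3 or compound 4 remains open.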